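Thiophene to Pyridine on the Core: What to Expect

A few compounds are considered here, and "the series" means these few. Any claim that something is new, unique, unknown or untested is made for them only; others in the source may bear on it.

Of the compounds shown here, three have so far been measured in a functional assay on HCT-116 cells (Homo sapiens) for inhibition, read by sulforhodamine B assay, with a stated time of 72 h; a lower number here means a stronger inhibitor, a higher number a weaker inhibitor. Compound 1 `COc1ccc(OC)c(C(=O)/C=C/c2cn(-c3ccccc3)nc2-c2ccsc2)c1` gives 3400 nM, the highest number of the three. Compound 2 `COc1ccc(C(=O)/C=C/c2cn(-c3ccccc3)nc2-c2ccsc2)c(OC)c1` gives 2200 nM; the step of a 1.5-fold lower number from compound 1 to compound 2 (0.19 log units; within the scatter) puts a 2,4-dimethoxyphenyl in place of the 2,5-dimethoxyphenyl on the carbonyl carbon and stays within the scatter. Among the compounds with values here, compound 3 `COc1ccc(C(=O)/C=C/c2cn(-c3ccccc3)nc2-c2cccnc2)c(OC)c1OC` gives 1100 nM, the lowest number, but it differs from compound 1 in two places, at the aryl on the carbonyl carbon and at the five-membered aromatic ring with 2 nitrogen, so its two values with compound 1 show only that this pair lies beyond the scatter, not which change carries it.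

Compound 4 `COc1ccc(OC)c(C(=O)/C=C/c2cn(-c3ccccc3)nc2-c2cccnc2)c1` has not been measured. It differs from compound 1 by pyridin-3-yl in place of thiophen-3-yl on an aromatic carbon, next to the ring nitrogen and next to the ring atom that bears a large group. Within the data shown here, no measured step isolates this exchange; the only single-place step, from compound 1 to compound 2, concerns the other aryl. The lower number of compound 3, which carries the same pyridin-3-yl, is the only hint. Compound 4 is therefore expected to land near compound 1, with the step of a 1.4-fold lower number from compound 1 to compound 4 (0.13 log units; within the scatter) expected to stay within the scatter. The estimate for compound 4 in this assay is 2500 nM, ranging from 1000 nM to 6000 nM.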

Compound 4, half-maximal inhibitory concentration: 1000 nM
Compound 4: middle estimate off by 2.5-fold (0.40 log units), on the high side, and the stated range covers the measured number.
By their numbers in this assay, from the lowest: compounds 4, 3, 2 and 1 (each within the scatter of the next, the first and the last beyond it).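

In this assay, the exchange of thiophen-3-yl for pyridin-3-yl on an aromatic carbon of the five-membered aromatic ring with 2 nitrogen now stands alone, and it gives a 3.4-fold lower number from compound 1 to compound 4 (0.53 log units; beyond the scatter). This is the only single-place step shown that lies beyond the scatter, whereas the change at the aryl on the carbonyl carbon, a 1.5-fold lower number from compound 1 to compound 2 (0.19 log units; within the scatter), does not, so among these compounds the clear difference belongs to this position rather than to the other aryl. Nothing measured here explains why the exchange has this effect.

Compound 3 at 1100 nM and compound 4 at 1000 nM lie within the scatter of each other, so the compounds shown leave open whether any change at the aryl on the carbonyl carbon matters once pyridin-3-yl is present, and whether the exchange would give a similar step with the 2,4-dimethoxyphenyl of compound 2. Going by these compounds, it also remains open whether a plain phenyl, a pyridin-4-yl or a furan-3-yl at this place would match pyridin-3-yl or stay closer to thiophen-3-yl.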